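This account rests on a few compounds, and the source may have more. Where it says the series, first, only, none or still open, it means among the compounds named here.

Series notes. Among the measured compounds shown here, compound 1 `O=C(Cc1ccccn1)c1cc2n(n1)CCCC2` is the only member with a number so far: in a functional assay on HEK293 cells for negative allosteric modulation of metabotropic glutamate receptor 5 (Rattus norvegicus), read by FLIPR and calcium flux, with a stated time of 170 s (on this read-out lower numbers stand for stronger inhibition and higher numbers for weaker inhibition), compound 1 gives 390 nM. Compound 2 `Cc1cccc(NC(=O)c2cc3n(n2)CCCC3)n1` is reported in this assay as "not active" (no number reported), so no value places it on the scale; where it stands is known only as giving no measurable inhibition, while compound 1 does, and the size of that gap cannot be stated. Compound 3 `O=C(Nc1cccc(F)n1)c1cc2n(n1)CCCC2` differs from compound 2 in one place: fluoro in place of methyl on an aromatic carbon. For the measured compounds named here, no pair of measured compounds shows this exchange, so no measured step gives a direction or a size; the only anchor is the absence of activity for compound 2 in this assay. The exchange is expected to bring compound 3 at most modestly into measurable inhibition in this assay, well short of compound 1. For compound 3 in this assay a half-maximal inhibitory concentration of 6000 nM is estimated, within a range from 1200 nM to 30000 nM, with a substantial chance that again no number is reported.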

Compound 3, half-maximal inhibitory concentration: 4740 nM
Beside the measured number, compound 3's estimate is 1.3-fold (0.10 log units) above it; the measured number falls inside the stated range.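

No step can be read from compound 2 to compound 3: compound 2 has no number to set against that of compound 3. The compounds shown leave open how much fluoro in place of methyl changes inhibition. No supporting data bear on this result.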